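Working notes: fluoro for trifluoromethyl, compound 1 to compound 3

The source may hold more compounds than are shown below. What is called first, only, known or untested is meant among the compounds shown, and "the series" means these compounds.

Measured so far in this series:
compound 1 `CCC(C(=O)N1CCN(c2ccc(C(F)(F)F)cc2)CC1)N1C(=O)CCC1=O`: 0%
compound 2 `CC(C(=O)N1CCN(c2ccccc2Cl)CC1)N1C(=O)CCC1=O`: 25%

In a functional assay on the whole organism (strain Swiss) with Mus musculus as the target, in the maximal electroshock model, with a stated time of 1 h, at a dose of 300 mg/kg by the intraperitoneal route (on this read-out lower numbers stand for a weaker effect and higher numbers for a stronger effect at the one dose given), compound 1 gives 0%, the lowest of the two numbers shown. Compound 2 gives 25%, a number higher by more than the usual scatter. For the measured compounds named here, compound 2 differs from compound 1 in more than one place, so the two values show only that the pair spans a wide range; no single change can be read from them.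

Compound 3 `CCC(C(=O)N1CCN(c2ccc(F)cc2)CC1)N1C(=O)CCC1=O` has not yet been measured. Its difference from compound 1: fluoro in place of trifluoromethyl on an aromatic carbon

Going by the values given here, no step between measured compounds covers this change, so there is no measured precedent for its size. The step from compound 1 to compound 3 is expected to be small and upward, a number 15 percentage points higher from compound 1 to compound 3 (beyond the scatter), near the edge of the scatter. For compound 3 the estimate is 15%, with a range from 0% to 40%, the lower end set where compound 1 stands because compound 1 gives 0%.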

Compound 3, a percentage reported as activity, at one dose (the size of the read-out at that dose, not a potency): 25%
Compound 3: the middle estimate sits 10 percentage points below what was measured; measured number inside the range.
By their numbers in this assay, from the lowest: compound 1; then compounds 2 and 3 (each within the scatter of the next).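

In this assay, for the compounds shown here, the change to fluoro in place of trifluoromethyl gives a number 25 percentage points higher from compound 1 to compound 3 (beyond the scatter) and is the first step that can be read at a single place. It shows that the read-out responds to the group on this aromatic carbon, para to a large group, with the rest of compound 1 unchanged and with no ring, hydrogen-bond donor, hydrogen-bond acceptor or net charge entering or leaving. Nothing measured here accounts for the size or direction of this step.

Only fluoro and trifluoromethyl are shown at this position, so the effect of a methoxy group, a nitrile or plain hydrogen there remains open. Also open, from the compounds shown here alone, is whether the same change would give a similar step on a core with a different chain.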